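The source may report more compounds than this note shows. Statements on the series, on what has been measured and on what is new or still open speak of the compounds shown alone.

Three compounds of the series share one core and differ only in the aryl on a nitrogen on an aromatic ring. Compound 1 `Cc1ccc(Nc2cc(NC(=O)Nc3c(Cl)cccc3Cl)ncn2)cc1F` gives 85.3% in a functional assay on HCC827 cells (Homo sapiens) for inhibition, read by MTT assay, with a stated time of 48 h, tested at 10 uM; on this read-out higher numbers stand for more inhibition at the one concentration tested (going by the name of the read-out) and lower numbers for less inhibition. Compound 2 `COc1ccc(F)cc1Nc1cc(NC(=O)Nc2c(Cl)cccc2Cl)ncn1` gives 78%, with a number 7.3 percentage points lower from compound 1 to compound 2 (within the scatter). Compound 3 `COc1ccc(Br)cc1Nc1cc(NC(=O)Nc2c(Cl)cccc2Cl)ncn1` gives 53%, the lowest of the three numbers; the steps down to it are a number 32.3 percentage points lower from compound 1 to compound 3 (beyond the scatter) and a number 25 percentage points lower from compound 2 to compound 3 (beyond the scatter), both beyond the scatter. Compound 4 `CCc1ccc(Nc2cc(NC(=O)Nc3c(Cl)cccc3Cl)ncn2)cc1` is not yet measured in this assay. Its change from compound 3: 4-ethylphenyl in place of 5-bromo-2-methoxyphenyl on a nitrogen on an aromatic ring. The entering 4-ethylphenyl is closer in kind to the 3-fluoro-4-methylphenyl of compound 1 than to the 5-bromo-2-methoxyphenyl it replaces. Among the compounds with values here, no step between compound 1 and compound 4 has been measured; what the numbers show is that compound 1 gives 85.3% while compound 3 gives 53%. Of the measured steps, a number 32.3 percentage points lower from compound 1 to compound 3 (beyond the scatter) bears most on this change, the same 5-bromo-2-methoxyphenyl leaving the same place in reverse. An upward step beyond the scatter is therefore expected, estimated as a number 27 percentage points higher from compound 3 to compound 4 (beyond the scatter). Compound 4 is expected to give about 80%, with a range of 60% to 92%.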

Compound 4, a percentage reported as inhibition, at one concentration (the size of the read-out at that concentration, not a potency): 58%
For compound 4 the middle estimate is 22 percentage points above the measured one; the measured number lies below the stated range.
By their numbers in this assay, from the lowest: compounds 3 and 4 (each within the scatter of the next); then compounds 2 and 1 (each within the scatter of the next).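

In this assay, the step to the 4-ethylphenyl, with its oxygen and bromine gone, reads a number 5 percentage points higher from compound 3 to compound 4 (within the scatter), so losing the 5-bromo-2-methoxyphenyl does not by itself bring the number back to that of compound 1. The 4-ethylphenyl also does not behave like the 3-fluoro-4-methylphenyl at this nitrogen, with a number 27.3 percentage points lower from compound 1 to compound 4 (beyond the scatter), so a resemblance between these two aryl groups does not carry over into the read-out. With a number 20 percentage points lower from compound 2 to compound 4 (beyond the scatter) as well, the methoxy group no longer sorts the series: the two methoxy-bearing compounds, compound 2 and compound 3, lie apart beyond the scatter, and so do the two without it, compound 1 and compound 4.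

Nothing available bears on the reason for these steps. Still open, as far as these compounds go, is whether the gap between compound 1 and compound 4 follows the fluoro or the length of the alkyl chain, which a 3-fluoro-4-ethylphenyl or a plain 4-methylphenyl on the same nitrogen would separate.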